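A Sulfonyl Aryl Swap Toward Compound 4

A few compounds are considered here, and "the series" means these few. Any claim that something is new, unique, unknown or untested is made for them only; others in the source may bear on it.

Compound 2 `CC1CCN(c2c(S(=O)(=O)c3ccc(Cl)cc3)cnc3cc(F)ccc23)CC1` gives 90% in an assay on isolated protein for displacement of a labelled ligand from metabotropic glutamate receptor 5 (Homo sapiens), with a stated time of 60 min, tested at 1 uM (on this read-out lower numbers stand for less inhibition and higher numbers for more inhibition at the one concentration tested (going by the name of the read-out)), and stands second highest of the three numbers: compound 3 `CC1CCN(c2c(S(=O)(=O)c3ccc(Cl)cc3)cnc3cc(Cl)ccc23)CC1` gives 91%, and compound 1 `COc1ccc(S(=O)(=O)c2cnc3cc(F)ccc3c2N2CCC(C)CC2)cc1OC` gives 83%, both within the scatter of compound 2. Compound 4 `CC1CCN(c2c(S(=O)(=O)c3cc(F)cc(F)c3)cnc3cc(F)ccc23)CC1` differs from compound 2 by 3,5-difluorophenyl in place of 4-chlorophenyl on a sulfonyl sulfur. Within the data shown here, the one measured step at the same place, a number 7 percentage points higher from compound 1 to compound 2 (within the scatter), is within the scatter; the step of a number 1 percentage points higher from compound 2 to compound 3 (within the scatter) lies elsewhere and is also within the scatter. On these numbers the account expects no step beyond the scatter in this assay from compound 2 to compound 4, with a small drop possible. Compound 4 is therefore estimated at 85%, within 70% to 95%. The expected step is a number 5 percentage points lower from compound 2 to compound 4 (within the scatter).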

Compound 4, a percentage reported as inhibition, at one concentration (the size of the read-out at that concentration, not a potency): 77%
The estimate for compound 4 lay 8 percentage points above the measured number; measured number inside the range.
By their numbers in this assay, from the lowest: compounds 4, 1, 2 and 3 (each within the scatter of the next, the first and the last beyond it).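

At the sulfonyl sulfur, the choice of aryl group now produces a step beyond the scatter in this assay: 3,5-difluorophenyl in place of 4-chlorophenyl gives a modest drop (a number 13 percentage points lower from compound 2 to compound 4 (beyond the scatter)). The same group in place of 3,4-dimethoxyphenyl gives a step that stays within the scatter (a number 6 percentage points lower from compound 1 to compound 4 (within the scatter)), so the size of the change depends on the group that leaves. Nothing available accounts for this difference.

Still open, as far as these compounds go, is how a morpholine or a cyclohexyl group on the sulfonyl sulfur would compare. Also open, from the compounds shown here alone, is whether 3,5-difluorophenyl would give a similar step with chloro in place of fluoro on the aromatic carbon of the shared core.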